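From chloro to trifluoromethyl on the shared core

The compounds below may be only part of what the source reports. "The series", "measured", "known", "first", "only" and "open" are said of these compounds alone.

Compound 1 `c1ccc(Cn2ccc3nc(-c4ccccc4)nc-3c2)cc1`: > 100000 nM
Compound 2 `COc1ccc(Cn2ccc3nc(-c4ccccc4)nc-3c2)cc1`: > 100000 nM
Compound 3 `Clc1ccc(Cn2ccc3nc(-c4ccccc4)nc-3c2)cc1`: > 100000 nM

In an ADME assay on MDBK cells (Bos taurus) for cytotoxicity (on this read-out lower numbers stand for higher toxicity in this test and higher numbers for lower toxicity in this test), compound 3 gives > 100000 nM, which is a limit of the assay and not a number. It has no position of its own within the series, since all the measured compounds share one reading: the limit of > 100000 nM in this assay, at which 3 of the 3 values shown sit.

Compound 4 `FC(F)(F)c1ccc(Cn2ccc3nc(-c4ccccc4)nc-3c2)cc1` carries trifluoromethyl in place of chloro on an aromatic carbon of a six-membered aromatic ring of carbon only, para to a large group: trifluoromethyl in place of chloro on an aromatic carbon.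

Among the compounds with values here, three measured steps bear on this change. Within the data shown here, the first is a step that the two limits leave unreadable from compound 1 to compound 3. The second is a step that the two limits leave unreadable from compound 2 to compound 3. The third is a step that the two limits leave unreadable from compound 1 to compound 2. None of them offers a size that could be carried over to the new group, so the expectation rests on the reading of compound 3, which is > 100000 nM. In this assay no step beyond the scatter is expected, in either direction, and compound 4 is expected to report a limit as well.

The expected step is a number no higher from compound 3 to compound 4 (the limit leaves the size open), an estimate that stays within the scatter. For compound 4 the estimated value is 100000 nM. The expected range for compound 4 runs from 60000 nM to 200000 nM.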

Compound 4, half-maximal cytotoxic concentration: 84000 nM
Compound 4: middle estimate off by 1.2-fold (0.08 log units), on the high side, and the stated range covers the measured number.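

In this assay, within the data shown here, compound 4 is the first of the series to give a number and not a limit, so trifluoromethyl on this aromatic carbon, para to a large group, yields the first step here that can be read, though only as a floor: an at least 1.1-fold lower number from compound 3 to compound 4 (0.07 log units; that floor lies within the scatter). Measured against the other two groups the result is the same, with an at least 1.1-fold lower number from compound 2 to compound 4 (0.07 log units; that floor lies within the scatter) and an at least 1.1-fold lower number from compound 1 to compound 4 (0.07 log units; that floor lies within the scatter), so each of these floors stays within the scatter and none of them shows a change beyond it. The three other compounds remain together at one reading: the limit of > 100000 nM in this assay, at which 3 of the 4 values shown sit.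

From the compounds shown here alone, the steps among compound 1, compound 2 and compound 3 cannot be read, and how far any of these three truly lies from compound 4 remains open. Also open, going by these compounds, is whether a nitrile, an amine or a carboxylic acid on this same aromatic carbon would give a number or a limit in this assay, and whether any group there would produce a step beyond the scatter.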